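Methylating a Phenolic Hydroxyl: Compound 3 to Compound 4

The source may report more compounds than this note shows. Statements on the series, on what has been measured and on what is new or still open speak of the compounds shown alone.

Measured so far:
compound 1 `COc1cc(Cl)cc(-c2nn(-c3cccc(NC(=O)Nc4cc(C(F)(F)F)cc(C(F)(F)F)c4)c3)cc2-c2ccncc2)c1` — 21.7%
compound 2 `COc1cc(Cl)cc(-c2nn(-c3cccc(NC(=O)c4cccc(C(F)(F)F)c4)c3)cc2-c2ccncc2)c1` — 84.1%
compound 3 `O=C(Nc1cccc(-n2cc(-c3ccncc3)c(-c3cc(O)cc(Cl)c3)n2)c1)c1cc(C(F)(F)F)cc(C(F)(F)F)c1` — 70.7%

In a functional assay on OVCAR-5 cells (Homo sapiens) for inhibition, read by sulforhodamine B assay, with a stated time of 48 h, tested at 10 uM (a higher number here means a weaker effect of the compound at the concentration tested, a lower number a stronger effect), compound 3 stands second highest of the three numbers. Its nearest neighbour is compound 2, whose number is higher by a gap beyond the scatter; compound 1 lies far lower, also beyond the scatter. Compound 4 `COc1cc(Cl)cc(-c2nn(-c3cccc(NC(=O)c4cc(C(F)(F)F)cc(C(F)(F)F)c4)c3)cc2-c2ccncc2)c1` is not yet measured. It differs from compound 3 only in this: methyl in place of hydrogen on an oxygen on an aromatic ring — hydroxy becomes methoxy, or 3-chloro-5-hydroxyphenyl becomes 3-chloro-5-methoxyphenyl. Among the measured compounds shown here, no measured pair shows this change alone, so the expected step of a number 2.7 percentage points lower from compound 3 to compound 4 (within the scatter) is small, not beyond the scatter in either direction. Compound 4 is therefore expected to give about 68%, within a range from 40% to 92%.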

Compound 4, a percentage reported as activity, at one concentration (the size of the read-out at that concentration, not a potency): 83%
Compound 4: the middle estimate sits 15 percentage points below what was measured; the measured number falls inside the stated range.
By their numbers in this assay, from the lowest: compound 1; then compound 3; then compounds 4 and 2 (each within the scatter of the next).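

In this assay, methyl in place of hydrogen on this oxygen gives a number 12.3 percentage points higher from compound 3 to compound 4 (beyond the scatter), so here hydroxy goes with a stronger effect at the concentration tested than methoxy. The other new pair, trifluoromethyl in place of hydrogen on an aromatic carbon, stays within the scatter, with a number 1.1 percentage points lower from compound 2 to compound 4 (within the scatter). Nothing in the data explains either result. Going by these compounds, whether an ethoxy group or an amine at this position would match hydroxy or methoxy remains open. So does whether the hydroxy preference holds on other compounds of this series, such as the urea compound 1.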